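The source may report more compounds than this note shows. Statements on the series, on what has been measured and on what is new or still open speak of the compounds shown alone.

Measured compounds:
`O=C(Nc1cc(F)cc2c(=O)cc(C(=O)O)oc12)c1ccc(Cl)c(Cl)c1` compound 1, 2650 nM
`COc1ccc(C(=O)Nc2cc(Cl)cc3c(=O)cc(C(=O)O)oc23)cc1` compound 2, 1830 nM
`O=C(Nc1cc(Br)cc2c(=O)cc(C(=O)O)oc12)c1ccc(Cl)c(Cl)c1` compound 3, 3250 nM

In an assay on CHO cells for agonist activity at G protein-coupled receptor GPR35 (Rattus norvegicus), read by a beta-galactosidase reporter and beta-arrestin recruitment, with a stated time of 90 min (on this read-out lower numbers stand for an effect already at smaller amounts and higher numbers for an effect only at larger amounts of compound), compound 1 gives 2650 nM. Compound 3 differs from it only by a 1.2-fold higher number from compound 1 to compound 3 (0.09 log units; within the scatter), and compound 2 gives 1830 nM; all three numbers lie within the scatter of one another, so none can be called the more active.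

Compound 4 `O=C(O)c1cc(=O)c2cc(F)cc(NC(=O)c3cccc(Cl)c3Cl)c2o1` keeps the same atoms as compound 1, joined differently: 2,3-dichlorophenyl in place of 3,4-dichlorophenyl on a carbonyl carbon. Among the measured compounds shown here, no measured step touches the dichlorophenyl part of the molecule; the one step on hand, a 1.2-fold higher number from compound 1 to compound 3 (0.09 log units; within the scatter), concerns the core instead. With no guidance for this change, the expected step of a 1.3-fold higher number from compound 1 to compound 4 (0.12 log units; within the scatter) in this assay is small and of uncertain direction, and compound 4 is estimated at 3500 nM, within 1200 nM to 10000 nM.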

Compound 4, half-maximal effective concentration: 3130 nM
Estimate against measurement, compound 4: 1.1-fold (0.05 log units) above, and the stated range covers the measured number.
By their numbers in this assay, from the lowest: compounds 2, 1, 4 and 3 (each within the scatter of the next).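

Putting 2,3-dichlorophenyl in place of 3,4-dichlorophenyl on the carbonyl carbon gives in this assay a 1.2-fold higher number from compound 1 to compound 4 (0.07 log units; within the scatter) and stays within the scatter. Among the compounds shown here, this is the first measured change at this part of the molecule, and rearranging the chlorines here produces no readable shift in either direction. No measurement at hand explains this result.

As far as these compounds go, whether a different group on this carbonyl carbon, such as a pyridine ring or a cyclohexyl group, would move the number beyond the scatter remains open.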